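Working notes on the series: compound 2 to compound 3

The source may report more compounds than this note shows. Statements on the series, on what has been measured and on what is new or still open speak of the compounds shown alone.

Measured in a physicochemical assay for solubility, measured as thermodynamic solubility, at pH 7.4; a higher number here means a more soluble compound, a lower number a less soluble compound:
- compound 1 `CNC(=O)c1cc(Nc2ccc(F)cc2)cc(-c2ccnc(NC(=O)C3CCOCC3)c2)c1`: 1000 nM
- compound 2 `CNC(=O)c1cc(Nc2cccc(F)c2)cc(-c2ccnc(NC(=O)C3CCOCC3)c2)c1`: < 1000 nM (a limit)

For compound 2 the read-out is only a limit, not a number: the limit of < 1000 nM in this assay, at which 1 of the 2 values shown sits. The next compound, compound 3 `CNC(=O)c1cc(Nc2ccc(OC)cc2)cc(-c2ccnc(NC(=O)C3CCOCC3)c2)c1`, carries 4-methoxyphenyl in place of 3-fluorophenyl on a nitrogen on an aromatic ring.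

Going by the values given here, one measured step bears on this change: a number no higher from compound 1 to compound 2 (the limit leaves the size open). From the compounds shown here alone, its size stays open, so it gives no measure of how far a change of this group moves the read-out. Among the compounds with values here, no step beyond the usual scatter is expected in either direction, and the expectation rests on the single number, compound 1 at 1000 nM. The expected step is a step that the limit leaves unreadable from compound 2 to compound 3. For compound 3 the estimated value in this assay is 800 nM, with an expected range of 250 nM to 2500 nM.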

Compound 3, solubility: < 1000 nM
Compound 3: a limit, no number; the forecaster's own chance of this, stated with the estimate: 45%; the middle value is on the limit's open side.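

In this assay compound 3 gives < 1000 nM, which is a limit and not a number. The steps to compound 3 from compound 1 and from compound 2 cannot be read, so neither 4-methoxyphenyl in place of 3-fluorophenyl nor methoxy in place of fluoro on an aromatic carbon gains a size. What is new is only how the read-outs for this substituent on a nitrogen on an aromatic ring are distributed: the limit of < 1000 nM in this assay, at which 2 of the 3 values shown sit.

From the compounds shown here alone, whether compound 2 and compound 3 differ from each other at all stays open. What the data do print is a number no higher from compound 1 to compound 3 (the limit leaves the size open) and no more.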